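The source may hold more compounds than are shown below. What is called first, only, known or untested is meant among the compounds shown, and "the series" means these compounds.

Compound 2, with the structure `CS(=O)(=O)c1cc(C(=O)N=C(N)N)ccc1C#N`, stands at the higher end of the two numbers gathered so far: in a functional assay for inhibition of sodium/hydrogen exchanger (Oryctolagus cuniculus) (a higher number here means a weaker inhibitor, a lower number a stronger inhibitor), compound 2 gives 140 nM, while compound 1, with the structure `Cc1cc(N2CCCCC2)c(S(C)(=O)=O)cc1C(=O)N=C(N)N`, gives 21 nM in this assay, a gap between the two that lies beyond the scatter. The two compounds differ in more than one place, so their values are set side by side without a step being counted between them.

Compound 3, with the structure `Cc1cc(C#N)c(S(C)(=O)=O)cc1C(=O)N=C(N)N`, is not yet measured. It departs from compound 2 by a single change: methyl in place of hydrogen on an aromatic carbon, a methyl in place of hydrogen on an aromatic carbon, ortho to a group of 6 heavy atoms, meta to the cyano group and para to the methylsulfonyl group.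

Among the measured compounds shown here, no pair of measured compounds separated only by this change is available, so the size of the step is open. The account expects a modest move toward a lower number, not far beyond the scatter, with a 1.6-fold lower number from compound 2 to compound 3 (0.19 log units; within the scatter) as the estimated step. Compound 3 is therefore estimated at 90 nM, within a range from 35 nM to 250 nM.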

Compound 3, half-maximal inhibitory concentration: 70 nM
The estimate for compound 3 lay 1.3-fold (0.11 log units) above the measured number; low and high end bracket the measured number.
By their numbers in this assay, from the lowest: compound 1; then compounds 3 and 2 (each within the scatter of the next).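

In this assay, methyl in place of hydrogen on the aromatic carbon ortho to a group of 6 heavy atoms, meta to a cyano group and para to a methylsulfonyl group gives a 2.0-fold lower number from compound 2 to compound 3 (0.30 log units; within the scatter) and so stays within the scatter; this position carries the methyl without a clear shift in either direction. Among the compounds shown here, compound 3 also gives the first single-place comparison with compound 1: cyano in place of piperidin-1-yl on an aromatic carbon gives a 3.3-fold higher number from compound 1 to compound 3 (0.52 log units; beyond the scatter) and lies beyond the scatter, so the compound with piperidin-1-yl holds the lower number with the methyl common to both. Nothing available accounts for either step.

Going by these compounds, whether the methyl step would stay this small with a piperidin-1-yl group in place of the cyano group remains open, as does the effect of an ethyl group or a chlorine atom at the methyl position. On these data alone, it is also open whether a smaller amine such as dimethylamino or an open-chain group such as methoxy would stand closer to piperidin-1-yl or to cyano.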